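A few compounds are considered here, and "the series" means these few. Any claim that something is new, unique, unknown or untested is made for them only; others in the source may bear on it.

Compound 1, `Nc1ccc(OCCCCCn2ccc(=O)[nH]c2=O)cc1` — > 100000 nM in an ADME assay on HEL cells (Homo sapiens) for cytotoxicity, read by microscopy; on this read-out higher numbers stand for lower toxicity in this test and lower numbers for higher toxicity in this test.
Compound 2, `CCCOC(=O)c1ccc(OCCCCCn2ccc(=O)[nH]c2=O)cc1` — >= 100000 nM in this assay.

In this assay compound 1 gives > 100000 nM, which is a limit of the assay and not a number. Compound 2 gives >= 100000 nM in this assay, also a limit. Both measured values sit at a ceiling, the limit of > 100000 nM in this assay, at which 1 of the 2 values shown sits, and (the limit of >= 100000 nM in this assay, at which 1 of the 2 values shown sits), so the step that the two limits leave unreadable from compound 1 to compound 2 cannot be read in size, and no cytotoxicity was seen for either compound within the tested range.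

Compound 3, `Cc1cccc(OCCCCCn2ccc(=O)[nH]c2=O)c1`, differs from compound 1 by 3-methylphenyl in place of 4-aminophenyl on an oxygen on a saturated carbon. Within the data shown here, the one measured step concerns a different group and is unreadable, so it offers no size to carry over; compound 1 is known only as a limit. Compound 3 is therefore expected to remain at that same ceiling, with an estimated value of 100000 nM and a range of 50000 nM to 200000 nM. This corresponds to an expected step of a number no higher from compound 1 to compound 3 (the limit leaves the size open), none beyond the scatter.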

Compound 3, minimum cytotoxic concentration: > 100000 nM
Compound 3: a limit, no number; the forecaster's own chance of this, stated with the estimate: 85%; the middle value sits exactly at the limit.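

Among these compounds, compound 1 and compound 3 both stand at a limit in this assay, so no step between them can be read. The compounds shown leave open at what concentration, if any, compound 1, compound 2 or compound 3 would become toxic to these cells.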